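Methoxycarbonyl onto the methanesulfonyl analogue

The compounds below may be only part of what the source reports. "The series", "measured", "known", "first", "only" and "open" are said of these compounds alone.

Two members of the series have been measured. Compound 1 `COC(=O)c1sc2cc(F)ccc2c1C1CCN(CC(O)Cn2nc(-c3ccc(C(F)(F)F)cc3)c3c2CCN(C(C)=O)C3)CC1` carries an acetyl group and a methoxycarbonyl group; in an assay on isolated protein for inhibition of cathepsin S (Homo sapiens) (on this read-out lower numbers stand for stronger inhibition and higher numbers for weaker inhibition), compound 1 gives 140 nM. Compound 2 `CS(=O)(=O)N1CCc2c(c(-c3ccc(C(F)(F)F)cc3)nn2CC(O)CN2CCC(c3csc4cc(F)ccc34)CC2)C1` carries a methanesulfonyl group and lacks the methoxycarbonyl; in this assay compound 2 gives 180 nM. The two values lie within the scatter of each other, so compound 2 and compound 1 are not separated by these data.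

Compound 3 `COC(=O)c1sc2cc(F)ccc2c1C1CCN(CC(O)Cn2nc(-c3ccc(C(F)(F)F)cc3)c3c2CCN(S(C)(=O)=O)C3)CC1` keeps the methanesulfonyl group of compound 2 and adds the ester: methoxycarbonyl in place of hydrogen on an aromatic carbon. Within the data shown here, no measured pair isolates this change, since compound 1 and compound 2 differ in two places at once, so the effect of the methoxycarbonyl alone is unknown here. Among the measured compounds shown here, the only guide is that both measured compounds, with and without the ester, fall close together in this assay.

On that basis the expected step from compound 2 to compound 3 in this assay is small, a 1.2-fold lower number from compound 2 to compound 3 (0.08 log units; within the scatter), with no direction beyond the scatter. Compound 3 is expected to give 150 nM in this assay, within 60 nM to 400 nM.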

Compound 3, half-maximal inhibitory concentration: 130 nM
For compound 3 the middle estimate is 1.2-fold (0.06 log units) above the measured one; low and high end bracket the measured number.
By their numbers in this assay, from the lowest: compounds 3, 1 and 2 (each within the scatter of the next).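

Among these compounds, compound 2 and compound 3 form the first pair that isolates methoxycarbonyl in place of hydrogen on an aromatic carbon, and in this assay the step is a 1.4-fold lower number from compound 2 to compound 3 (0.14 log units; within the scatter), so this place, next to the ring sulfur and next to the ring atom that bears a large group, takes a group of 4 heavy atoms with no step beyond the scatter. With the ester held constant, methylsulfonyl in place of acetyl on an amine nitrogen in a ring can now also be read alone, as a 1.1-fold lower number from compound 1 to compound 3 (0.03 log units; within the scatter), which leaves these two groups on that nitrogen unseparated in this assay. Nothing available explains why either change leaves the read-out within the scatter.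

The compounds shown hold only hydrogen and methoxycarbonyl at this aromatic carbon, so it remains open whether a carboxylic acid, a primary amide, a nitrile or a longer ester such as ethoxycarbonyl would give a step beyond the scatter. As far as these compounds go, the ester step is also read only with methanesulfonyl on the ring nitrogen, and whether it holds with acetyl there stays open.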